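Series notes: cytotoxicity readings sitting at the assay limit

The source may hold more compounds than are shown below. What is called first, only, known or untested is meant among the compounds shown, and "the series" means these compounds.

Measured so far:
- compound 1 `COc1ccc(C(=O)NNc2c(Br)cccc2Br)cc1` gives > 100000 nM in a toxicity assay on MDCK cells (Canis lupus familiaris) for cytotoxicity, read by CCK-8 assay, with a stated time of 48 h; on this read-out lower numbers stand for higher toxicity in this test and higher numbers for lower toxicity in this test; this value is a limit of the assay, not a number.
- compound 2 `O=C(NNc1c(Br)cccc1Br)c1ccc2ncccc2c1` gives > 100000 nM in this assay; again a limit.
- compound 3 `CCOc1ccc(C(=O)Nc2c(Br)cccc2Br)cc1` gives > 100000 nM in this assay; again a limit.

Compound 1 therefore stands nowhere in particular on the numbers shown: its reading is a limit, and the same holds for every other value here, as summed up by the limit of > 100000 nM in this assay, at which 3 of the 3 values shown sit. Among the compounds with values here, no pair of measured compounds differs in one place, so no measured step is available to lean on.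

Compound 4 `O=C(NNc1c(Br)cccc1Br)c1ccc(O)cc1` has not yet been measured in this assay. It differs from compound 1 by hydrogen in place of methyl on an oxygen on an aromatic ring.

With every measured value sitting at the limit, no step beyond the usual scatter is expected in either direction. For compound 4 the expected step is a step that the limit leaves unreadable from compound 1 to compound 4, and compound 4 is estimated at 150000 nM in this assay, with a range from 60000 nM to 400000 nM, most likely reported again as a limit rather than a number.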

Compound 4, half-maximal cytotoxic concentration: > 100000 nM
Compound 4 gave a limit, no number (the forecaster's own chance of this, stated with the estimate: 85%); the middle value lies beyond the limit too.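

No step can be read from compound 1 to compound 4, as both readings in this assay are limits and not numbers: the limit of > 100000 nM in this assay, at which 4 of the 4 values shown sit.

The compounds shown leave open whether methoxy to hydroxy changes the reading at all, and how far beyond the limit any of these compounds lies.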